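The source may report more compounds than this note shows. Statements on the series, on what has been measured and on what is new or still open speak of the compounds shown alone.

Working notes on the series.

Compound 1 `CC(C)(C)OC(=O)N1CC=C(c2cn(-c3ccc(F)cc3)nn2)CC1` is the reference point. In a functional assay on CHO cells for antagonist activity at metabotropic glutamate receptor 1 (Homo sapiens), read by FLIPR and calcium flux (on this read-out higher numbers stand for weaker inhibition and lower numbers for stronger inhibition), compound 1 gives 16 nM. Compound 2 `Cc1ccccc1-n1cc(C2=CCN(C(=O)OC(C)(C)C)CC2)nn1` keeps the shared core and carries a 2-methylphenyl in place of the 4-fluorophenyl on the aromatic nitrogen; in this assay compound 2 gives 11 nM. The step of a 1.5-fold lower number from compound 1 to compound 2 (0.16 log units; within the scatter) shows that this aryl exchange on the aromatic nitrogen leaves the read-out essentially where it was. On the two numbers in hand, compound 2 and compound 1 sit within the scatter of each other, so no ranking between them can be claimed.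

Compound 3 `CC(C)(C)OC(=O)N1CC=C(c2cn(-c3ccccn3)nn2)CC1` is not yet measured. It differs from compound 2 only at the aromatic nitrogen: pyridin-2-yl in place of 2-methylphenyl on an aromatic nitrogen. Among the measured compounds shown here, the one measured step that bears on this change is the aryl swap at the same position, a 1.5-fold lower number from compound 1 to compound 2 (0.16 log units; within the scatter), which stayed within the scatter. For the measured compounds named here, with only that precedent, the swap to pyridin-2-yl is expected to give no change beyond the scatter, with a wider range allowed since a ring with a hetero atom has not been tested here. The expected step is a 1.8-fold higher number from compound 2 to compound 3 (0.26 log units; within the scatter); compound 3 is therefore estimated at 20 nM in this assay, with a range from 6 nM to 70 nM.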

Compound 3, half-maximal inhibitory concentration in the metabotropic glutamate receptor 1 assay: 49 nM
The estimate for compound 3 lay 2.5-fold (0.39 log units) below the measured number, within the range that was stated.
By their numbers in the metabotropic glutamate receptor 1 assay, from the lowest: compounds 2 and 1 (each within the scatter of the next); then compound 3.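

In the metabotropic glutamate receptor 1 assay, the position on the aromatic nitrogen now gives steps beyond the scatter: a 4.5-fold higher number from compound 2 to compound 3 (0.65 log units; beyond the scatter), and a 3.1-fold higher number from compound 1 to compound 3 (0.49 log units; beyond the scatter), both modest. The two aryl groups with a ring of carbon only, 2-methylphenyl and 4-fluorophenyl, stand within the scatter of each other, whereas pyridin-2-yl, the one ring here with a hetero atom and a hydrogen-bond acceptor, gives the higher number against either of them. The position therefore does not accept every aromatic ring alike, although the change remains modest and rests on this one heteroaromatic group.

In a physicochemical assay for lipophilicity, using the shake flask method, measured as octanol-water partition, at pH 7.4 (a lower number here means a more polar compound, a higher number a more lipophilic compound), compound 2 gives > 4, which is a limit of the assay and not a number. In the physicochemical assay compound 3 gives > 4, which is likewise a limit of the assay and not a number. Going by these compounds, in the physicochemical assay the step from compound 2 to compound 3 cannot be read, and lipophilicity offers no account of the change, since both values are a limit of the assay and not numbers: the limit of > 4 in the physicochemical assay, at which 2 of the 2 values shown sit. What remains open is how unsubstituted phenyl would stand, which would help separate the ring nitrogen of pyridin-2-yl from the loss of the substituent, and whether pyridin-3-yl or a phenyl ring bearing an amine would follow compound 3.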